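The source may hold more compounds than are shown below. What is called first, only, known or untested is meant among the compounds shown, and "the series" means these compounds.

Compound 1 `COc1cc(O)c(C(=O)/C=C/c2ccc(F)cc2)c(OC)c1`: > 20000 nM
Compound 2 `COc1cccc(/C=C/C(=O)c2c(OC)cc(OC)cc2OC)c1`: > 20000 nM
Compound 3 `COc1cc(O)c(C(=O)/C=C/c2ccccc2OC)c(OC)c1`: > 20000 nM

These three entries come from an ADME assay on cells (Fibroblast, Homo sapiens) for cytotoxicity, with a stated time of 48 h (on this read-out higher numbers stand for weaker inhibition and lower numbers for stronger inhibition), and each is a limit of the assay, not a number. Compound 2 stands at the limit of > 20000 nM in this assay, at which 3 of the 3 values shown sit. Its exact place relative to compound 1 and compound 3 therefore cannot be read from these results.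

Compound 4 `COc1cc(OC)c(C(=O)/C=C/c2ccc(Cl)cc2)c(OC)c1` has not yet been measured. It carries 4-chlorophenyl in place of 3-methoxyphenyl on a double-bonded chain carbon bound to a double-bonded chain carbon. Within the data shown here, no pair of measured compounds shows a single change of this kind, so there is no measured step to borrow. Among the measured compounds shown here, the only guide is that compound 2 and both of its relatives sit at the same limit. In this assay, no step beyond the usual scatter is expected, and compound 4 may well be reported only as a limit too. The expected change is a number no higher from compound 2 to compound 4 (the limit leaves the size open). For compound 4, the estimate is 20000 nM, with an expected range of 8000 nM to 40000 nM.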

Compound 4, half-maximal inhibitory concentration: > 20000 nM
Compound 4: only a limit was reported; the forecaster's own chance of this, stated with the estimate: 70%; the middle value lies on the limit itself.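

In this assay compound 4 gives > 20000 nM, which is a limit and not a number. Among these compounds, compound 2 also has only a limit, so no step between compound 2 and compound 4 can be read. The compounds shown leave open how their true cytotoxicity values compare.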